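This account rests on a few compounds, and the source may have more. Where it says the series, first, only, none or still open, it means among the compounds named here.

In a functional assay on U226 cells (Homo sapiens) for cytotoxicity (on this read-out lower numbers stand for an effect already at smaller amounts and higher numbers for an effect only at larger amounts of compound), compound 1 `CC(=O)SCC(=O)c1ccc(NS(=O)(=O)c2ccc(OC3CCCN(C)C3)cc2)nc1` gives 1200 nM, and compound 2 `CC(=O)SCC(=O)c1ccc(NS(=O)(=O)c2ccc(OCCCN3CCCC3)cc2)nc1` gives 400 nM. For the measured compounds named here, the one change between them, a 3.0-fold lower number from compound 1 to compound 2 (0.48 log units; beyond the scatter), is the only measured step here. As far as these compounds go, compound 3 `CC(=O)SCC(=O)c1ccc(NS(=O)(=O)c2ccc(OCCCc3ccccn3)cc2)nc1` gives "not determined" (no result reported) in this assay, so its standing is unknown. Compound 4 `CC(=O)SCC(=O)c1ccc(NS(=O)(=O)c2ccc(OCCCN3CCCCC3)cc2)nc1` differs from compound 3 by piperidin-1-yl in place of pyridin-2-yl on a saturated chain carbon, three bonds along the chain from an oxygen on an aromatic ring. Going by the values given here, no step in the data matches this exact change; the nearest guide is compound 2, whose chain also ends in a saturated nitrogen ring and which gives 400 nM. Compound 4 is therefore expected to come out near that, with an estimated value of about 500 nM, within a range from 150 nM to 1500 nM, in this assay.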

Compound 4, half-maximal effective concentration: 800 nM
For compound 4 the middle estimate is 1.6-fold (0.20 log units) below the measured one; the range from low to high includes it.
By their numbers in this assay, from the lowest: compounds 2, 4 and 1 (each within the scatter of the next, the first and the last beyond it).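

In this assay, piperidin-1-yl in place of pyrrolidin-1-yl on this chain carbon gives a 2.0-fold higher number from compound 2 to compound 4 (0.30 log units; within the scatter), so these two saturated rings cannot be told apart here. 3-(Piperidin-1-yl)propyl in place of 1-methylpiperidin-3-yl on the oxygen gives a 1.5-fold lower number from compound 1 to compound 4 (0.18 log units; within the scatter), so this swap cannot be told apart either, even though compound 1 and compound 2 differ beyond the scatter. No evidence is available to explain these results.

The step from pyridin-2-yl to piperidin-1-yl cannot be read, as compound 3 has no number. Also open, as far as these compounds go, is how a morpholine ring or a dimethylamino group would read on the same chain carbon.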